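Reversing the Ester on a Furan-Bearing Naphthalene Core

A few compounds are considered here, and "the series" means these few. Any claim that something is new, unique, unknown or untested is made for them only; others in the source may bear on it.

Compound 2 `CCOC(=O)c1c(C)coc1-c1ccc2c(CC)cccc2c1OC` is the reference point of this small set. Within the data shown here, in a functional assay on A549 cells (Homo sapiens) for cytotoxicity, read by MTT assay, with a stated time of 72 h (on this read-out lower numbers stand for an effect already at smaller amounts and higher numbers for an effect only at larger amounts of compound), compound 2 gives 3.8 ug/mL, and this is the only outright number in the study. The two other values shown are limits of the assay. Compound 1 `CCOc1c(-c2occ(C)c2C(=O)O)ccc2c(CC)cccc12` carries a free acid where compound 2 carries the ester, and in this assay compound 1 gives > 10 ug/mL, a limit of the assay rather than a number. Compound 3 `CCOCc1c(C)coc1-c1ccc2c(CC)cccc2c1OC` carries an ethoxymethyl group in the same place, and in this assay compound 3 gives > 10 ug/mL, again a limit.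

Among the measured compounds shown here, the one measured step that can be read as a number is an at least 2.6-fold higher number from compound 2 to compound 3 (0.42 log units; beyond the scatter); it shows that trading the ethoxycarbonyl for a group without its carbonyl weakens the effect, though the true size of the loss is hidden by the limit (the limit of > 10 ug/mL in this assay, at which 2 of the 3 values shown sit).

Compound 4 `CCc1cccc2c(OC)c(-c3occ(C)c3COC(C)=O)ccc12` is the unmeasured case. It differs from compound 2 as follows: acetoxymethyl in place of ethoxycarbonyl on an aromatic carbon. The ester is kept but turned around, so the step from compound 2 to compound 3 bears on it only in part. A modest weakening is expected, a 1.8-fold higher number from compound 2 to compound 4 (0.27 log units; within the scatter), with a real chance that only a limit is reached. Compound 4 is therefore estimated at 7 ug/mL, between 3.5 ug/mL and 14 ug/mL.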

Compound 4, concentration for half-maximal effect: > 10 ug/mL
Compound 4 was reported as a limit; the forecaster's own chance of this, stated with the estimate: 35%; middle value at least 1.4-fold (0.15 log units) away from the limit.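

In this assay, among these compounds, the step is an at least 2.6-fold higher number from compound 2 to compound 4 (0.42 log units; beyond the scatter), and this is what the earlier compounds could not show. Compound 3 had lost the carbonyl of the ester, so its weaker result left open whether a carbonyl at this spot on the furan-type ring was enough to keep the effect. Compound 4 keeps a carbonyl and swaps ethoxycarbonyl for acetoxymethyl, two groups with the same atoms joined differently, and the effect still weakens, so in this small set the way the ester is attached matters and not just the atoms it contains.

The value of compound 4 is a limit of the assay, so the full size of its loss stays hidden, and the step between compound 3 and compound 4 cannot be read, because both stand at the same limit: the limit of > 10 ug/mL in this assay, at which 3 of the 4 values shown sit.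

The compounds shown leave open whether any group other than ethoxycarbonyl can hold the effect at this position, such as a primary amide or an amine on a short chain. They also do not tell whether a longer chain on the ester, as in a butyl ester, would keep, lose or improve the effect of compound 2.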